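This account rests on a few compounds, and the source may have more. Where it says the series, first, only, none or still open, it means among the compounds named here.

Compound 1 `COc1cc2ncnc(NNC(=S)NC(=O)c3ccccc3OC)c2cc1OC` — 8800 nM
Compound 2 `COc1ccccc1C(=O)NC(=S)NNc1ncnc2ccccc12` — 8700 nM

Both compounds were tested in a functional assay on MCF7 cells (Homo sapiens) for cytotoxicity, read by MTT assay, with a stated time of 72 h; on this read-out higher numbers stand for weaker inhibition and lower numbers for stronger inhibition. Compound 1 gives 8800 nM and compound 2 gives 8700 nM; the two numbers fall within the usual scatter of each other, so compound 1 stands level with compound 2 and neither can be ranked above the other. Compound 3 `COc1cc2ncnc(NNC(=S)NC(=O)c3ccccc3)c2cc1OC` has not yet been tested. It differs from compound 1 in a single place: hydrogen in place of methoxy on an aromatic carbon. For the measured compounds named here, no measured pair shows what such a change does here, so no shift beyond the scatter is expected, and compound 3 is estimated at 9000 nM, within 3000 nM to 27000 nM, an expected step of a 1.0-fold higher number from compound 1 to compound 3 (0.01 log units; within the scatter).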

Compound 3, half-maximal inhibitory concentration: 6990 nM
Compound 3: the middle estimate sits 1.3-fold (0.11 log units) above what was measured, within the range that was stated.
By their numbers in this assay, from the lowest: compounds 3, 2 and 1 (each within the scatter of the next).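

In this assay, for the compounds shown here, the change from 2-methoxyphenyl to phenyl gives a 1.3-fold lower number from compound 1 to compound 3 (0.10 log units; within the scatter) and is the first step read at this place. On the core of compound 1, the methoxy on this aromatic carbon, ortho to a large group, can give way to hydrogen without a shift beyond the scatter. Nothing at hand gives a measured reason for this result.

The compounds shown leave open what an amine, a carboxylic acid or a chlorine atom would do at this place. They also leave open whether the same change on compound 2 would read alike.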